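Notes on the amide aryl variation in this series

The source may hold more compounds than are shown below. What is called first, only, known or untested is meant among the compounds shown, and "the series" means these compounds.

Compound 3 `Cc1cccc(NC(=O)c2cccc(/C=C3\CC(=O)N(c4ccccc4)C3=O)c2)c1` carries a 3-methylphenyl on the amide-type nitrogen. In an ADME assay on NCM460 cells (Homo sapiens) for cytotoxicity, read by MTT assay, with a stated time of 72 h (a higher number here means a weaker inhibitor, a lower number a stronger inhibitor), compound 3 gives only a limit of the assay, > 100000 nM. Compound 1 `Cc1ccc(NC(=O)c2cccc(/C=C3\CC(=O)N(c4ccccc4)C3=O)c2)cc1` also reaches only the limit, > 100000 nM. Compound 2 `Cc1ccc(NC(=O)c2cccc(/C=C3\CC(=O)N(c4ccccc4)C3=O)c2)cc1C` likewise gives only the limit, > 100000 nM. The three measured steps, a step that the two limits leave unreadable from compound 1 to compound 2, a step that the two limits leave unreadable from compound 1 to compound 3 and a step that the two limits leave unreadable from compound 2 to compound 3, therefore tell nothing about size, because of the limit of > 100000 nM in this assay, at which 3 of the 3 values shown sit. Compound 4 `O=C(Nc1ccc(OC(F)F)cc1)c1cccc(/C=C2\CC(=O)N(c3ccccc3)C2=O)c1` differs from compound 3 by 4-(difluoromethoxy)phenyl in place of 3-methylphenyl on an amide-type nitrogen. Within the data shown here, no measured step in this assay covers this change directly, and the steps that exist cannot be read in either direction. The step expected in this assay for this change is a number no higher from compound 3 to compound 4 (the limit leaves the size open), meaning nothing beyond the scatter and most probably once more only a limit. Compound 4 is expected to give about 100000 nM, with a range from 40000 nM to 250000 nM.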

Compound 4, half-maximal inhibitory concentration: > 100000 nM
Compound 4: no number, only a limit; the forecaster's own chance of this, stated with the estimate: 80%; the middle value lies on the limit itself.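

Among these compounds, no step to compound 4 from compound 1, compound 2 or compound 3 can be read in this assay because all four compounds stop at one limit: (the limit of > 100000 nM in this assay, at which 4 of the 4 values shown sit). Going by these compounds, how these compounds differ in cytotoxicity, and whether any amide aryl group gives a measurable value, stays open.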